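A few compounds are considered here, and "the series" means these few. Any claim that something is new, unique, unknown or untested is made for them only; others in the source may bear on it.

Of the compounds shown here, three of one series have been measured so far. Compound 1 `O=C(NCc1ccncc1)Nc1ccc(S(=O)(=O)c2ccc(Cl)cc2)cc1` gives 126 nM in an assay on isolated protein for activation of Nicotinamide phosphoribosyltransferase (Homo sapiens) (on this read-out lower numbers stand for an effect already at smaller amounts and higher numbers for an effect only at larger amounts of compound), and stands second highest of the three numbers. Compound 2 `O=C(NCc1cn[nH]c1)Nc1ccc(S(=O)(=O)c2ccc(Cl)cc2)cc1` gives 23 nM, and the step of a 5.5-fold lower number from compound 1 to compound 2 (0.74 log units; beyond the scatter) lies beyond the usual scatter. Compound 3 `CCOC(=O)c1ccc(NC(=O)NCc2cnco2)cc1` gives 6900 nM; more than one part of its structure differs from compound 1, so no single step can be read from that pair. Compound 4 `O=C(NCc1ccncc1)Nc1ccc(S(=O)(=O)c2ccccc2)cc1` has not been measured. It differs from compound 1 by hydrogen in place of chloro on an aromatic carbon. Among the compounds with values here, none of the measured steps touches this position, so the expectation rests on no direct precedent. For compound 4 the step of a 2.0-fold higher number from compound 1 to compound 4 (0.30 log units; within the scatter) is expected, toward a somewhat higher number. The estimate for compound 4 is 250 nM, expected to fall between 80 nM and 800 nM.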

Compound 4, half-maximal effective concentration: 85 nM
The estimate for compound 4 lay 2.9-fold (0.47 log units) above the measured number; low and high end bracket the measured number.
By their numbers in this assay, from the lowest: compound 2; then compounds 4 and 1 (each within the scatter of the next); then compound 3.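

The step from chloro to hydrogen on this aromatic carbon, 4-chlorophenyl to phenyl, gives a 1.5-fold lower number from compound 1 to compound 4 (0.17 log units; within the scatter) in this assay. Until now, every compound with this ring carried the chloro group, so its role was untested; this pair shows that the chloro group can be replaced by hydrogen with no change beyond the scatter. Nothing available explains this result.

On these data alone, whether a methoxy group, an amine or a carboxylic acid at this place would give a similar number remains open. So does whether hydrogen in place of chloro would act the same way in compound 2.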